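The source may report more compounds than this note shows. Statements on the series, on what has been measured and on what is new or still open speak of the compounds shown alone.

Compound 2 `ClCc1ccccc1Cn1cnc2c(Cl)ncnc21` belongs to a small set of three measured compounds. Its closest relative is compound 1 `ClCc1ccccc1Cn1cnc2c(Cl)nc(Cl)nc21`, and a more distant one is compound 3 `ClCc1ccc(Cn2cnc3nc(Cl)nc(Cl)c32)cc1`, whose chloromethyl-bearing benzyl arm is attached to the shared core in a different way. In a functional assay on Hs-578T cells (Homo sapiens) for cytotoxicity, read by sulforhodamine B assay, with a stated time of 48 h (on this read-out lower numbers stand for stronger inhibition of growth and higher numbers for weaker inhibition of growth), compound 2 gives 2290 nM, the second highest of the three numbers. Compound 1 gives 1170 nM, and the step from compound 1 to compound 2, where hydrogen takes the place of a chloro group on an aromatic carbon, amounts to a 2.0-fold higher number from compound 1 to compound 2 (0.29 log units; within the scatter). Compound 3 gives 19100 nM, a number clearly higher than that of compound 2.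

Compound 4 `Nc1nc(Cl)c2ncn(Cc3ccccc3CCl)c2n1` changes the same aromatic carbon that carries chloro in compound 1 and hydrogen in compound 2: amino in place of hydrogen on an aromatic carbon. Among the measured compounds shown here, only one measured step exists, that from compound 1 to compound 2, and it involves a chloro group rather than an amino group, so it is an indirect guide at best; it did stay within the scatter, suggesting that this carbon tolerates a change without a large shift. For the measured compounds named here, no measured compound carries an amino group anywhere. On this thin basis compound 4 is expected to give about 2200 nM, within a range from 700 nM to 7000 nM. The expected step from compound 2 to compound 4 is a 1.0-fold lower number from compound 2 to compound 4 (0.02 log units; within the scatter), that is, no change beyond the scatter in either direction.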

Compound 4, concentration for 50% growth inhibition: 7760 nM
Compound 4: middle estimate off by 3.5-fold (0.55 log units), on the low side; measured number outside the range, above it.
By their numbers in this assay, from the lowest: compounds 1 and 2 (each within the scatter of the next); then compound 4; then compound 3.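

The carbon between two ring nitrogen atoms turns out not to be indifferent to what it carries: in this assay, amino in place of hydrogen gives a 3.4-fold higher number from compound 2 to compound 4 (0.53 log units; beyond the scatter). Amino in place of chloro on the same carbon points the same way, with a 6.6-fold higher number from compound 1 to compound 4 (0.82 log units; beyond the scatter), so amino goes with weaker inhibition of growth than either of the other two groups, while chloro and hydrogen stay within the scatter of each other. Among the compounds shown here, the earlier step therefore describes only that pair of groups, and its small size does not carry over to every group placed on this carbon.

Nothing at hand explains why the amino compound gives the higher number. Going by these compounds, it also stays open whether a methylamino, dimethylamino, hydroxyl or methoxy group on this carbon would behave like amino or like chloro and hydrogen, and whether amino would have a similar effect with the chloromethyl-bearing benzyl arm attached as in compound 3.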